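Trimethoxyphenyl enone pyrazoles: cytotoxicity notes on a small series

The compounds below may be only part of what the source reports. "The series", "measured", "known", "first", "only" and "open" are said of these compounds alone.

Measured compounds:
compound 1, `COc1cc(-c2cc(/C=C/C(=O)c3ccc(N)cc3)[nH]n2)cc(OC)c1OC`, 1%
compound 2, `COc1ccc(C(=O)/C=C/c2cc(-c3cc(OC)c(OC)c(OC)c3)n[nH]2)cc1OC`, -84%

In a functional assay on IGROV-1 cells (Homo sapiens) for cytotoxicity, read by sulforhodamine B assay, with a stated time of 48 h, tested at 10 uM (a higher number here means a weaker effect of the compound at the concentration tested, a lower number a stronger effect), compound 1 gives 1% and compound 2 gives -84%. Within the data shown here, compound 2 stands lowest of the two numbers; the only step measured, a number 85 percentage points lower from compound 1 to compound 2 (beyond the scatter), swaps the whole aryl group on the carbonyl carbon and is large.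

Compound 3 is `COc1cc(C(=O)/C=C/c2cc(-c3cc(OC)c(OC)c(OC)c3)n[nH]2)cc(OC)c1OC`. It differs from compound 2 by methoxy in place of hydrogen on an aromatic carbon. Among the measured compounds shown here, no measured step bears on this change: the single step in hand concerns a different group, not the entry of one more methoxy, so it gives no direct guide in this assay. With compound 2 already giving -84%, the working expectation is no step beyond the scatter, with some allowance for a weaker effect, estimated as a number 19 percentage points higher from compound 2 to compound 3 (beyond the scatter). Compound 3 is therefore expected to give about -65%, within -95% to 5%.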

Compound 3, a percentage reported as activity, at one concentration (the size of the read-out at that concentration, not a potency): 1%
Compound 3: the middle estimate sits 66 percentage points below what was measured; the range from low to high includes it.
By their numbers in this assay, from the lowest: compound 2; then compounds 1 and 3 (each within the scatter of the next).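

In this assay, methoxy in place of hydrogen gives a number 85 percentage points higher from compound 2 to compound 3 (beyond the scatter) on the aryl group at the carbonyl carbon. The earlier step replaced that whole aryl group, whereas this one shows that adding 2 heavy atoms at a single aromatic carbon, ortho to a methoxy group, is enough for a large step and removes the strong effect of compound 2 at the concentration tested. No measurement at hand accounts for this step.

As far as these compounds go, it remains open whether the loss belongs to methoxy itself or to any group at this carbon; a fluorine atom, a hydroxyl group or an ethoxy group at the same place would help separate the two. From the compounds shown here alone, whether the same step appears on other cell lines or at other concentrations also remains open.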